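This account rests on a few compounds, and the source may have more. Where it says the series, first, only, none or still open, it means among the compounds named here.

In a toxicity assay on cells (Macrophage, Mus musculus, strain BALB/c) for cytotoxicity, read by MTT assay (a lower number here means a stronger inhibitor, a higher number a weaker inhibitor), three compounds have been measured so far. Compound 1 `C=CCOc1cc(OC)c(C(=O)/C=C/Cc2ccccc2)c(OCC=C)c1` gives 14800 nM, and compound 3 `C=CCOc1cc(OC)c(C(=O)/C=C/c2ccccc2F)c(OCC=C)c1` gives 13300 nM. Compound 2 `COc1cc(O)cc(O)c1C(=O)/C=C/c1ccco1` gives 384000 nM, the highest of the three numbers and beyond the scatter from both of the others.

Compound 4 `COc1cc(O)cc(O)c1C(=O)/C=C/c1ccccc1F` shares its core with compound 2 and differs from it in one place: 2-fluorophenyl in place of furan-2-yl on a double-bonded chain carbon bound to a double-bonded chain carbon. Among the measured compounds shown here, only one measured step bears on this change, and only indirectly. In a 1.1-fold lower number from compound 1 to compound 3 (0.05 log units; within the scatter), the same 2-fluorophenyl enters, but in place of benzyl rather than furan-2-yl, and on a different core. That step stays within the scatter, so it gives no sign of a large change from 2-fluorophenyl itself. The gap between compound 2 and compound 3 spans both the core and this group, and the data cannot separate the two. Compound 3, carrying 2-fluorophenyl on its own core, gives 13300 nM, so a moderate move towards a lower number is expected, well short of that whole gap. The estimated change is a 3.2-fold lower number from compound 2 to compound 4 (0.51 log units; beyond the scatter). For compound 4 the expected value is 120000 nM, with an estimated range from 30000 nM to 400000 nM.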

Compound 4, half-maximal inhibitory concentration: 16000 nM
For compound 4 the middle estimate is 7.5-fold (0.88 log units) above the measured one; measured number outside the range, below it.
By their numbers in this assay, from the lowest: compounds 3, 1 and 4 (each within the scatter of the next); then compound 2.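

In this assay, among the compounds shown here, the earlier compounds offered only one step at this place, and it lay within the scatter (a 1.1-fold lower number from compound 1 to compound 3 (0.05 log units; within the scatter)), with 2-fluorophenyl replacing benzyl on the core of compound 1. The new result shows that the group on this double-bonded chain carbon can matter a great deal: on the shared core of compound 2 and compound 4, a single exchange of furan-2-yl for 2-fluorophenyl gives a large step (a 24-fold lower number from compound 2 to compound 4 (1.38 log units; beyond the scatter)), so the high number of compound 2 goes with its furan-2-yl group and not with that core alone. No measured evidence accounts for the size of this step.

The compounds shown leave open whether the step belongs to the fluorine or to the six-membered carbon ring as such, a question that plain phenyl or a thiophen-2-yl group at this place would address. They also leave open whether furan-2-yl would raise the number in the same way on the core of compound 1, which carries two allyloxy groups.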